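A few compounds are considered here, and "the series" means these few. Any claim that something is new, unique, unknown or untested is made for them only; others in the source may bear on it.

Compound 2 `COc1cc(C)cc(-c2nn(CC#N)cc2-c2ccnc(-c3ccc(N(C)C)cc3)c2)c1` holds the lowest of the two numbers recorded so far: in a functional assay on DU-145 cells (Homo sapiens) for inhibition, read by sulforhodamine B assay, with a stated time of 48 h (a higher number here means a weaker inhibitor of growth, a lower number a stronger inhibitor of growth), compound 2 gives 319 nM, while compound 1 `Cc1cc(O)cc(-c2nn(CC#N)cc2-c2ccnc(-c3ccc(Oc4ccccc4)cc3)c2)c1` gives 2280 nM, a gap well beyond the scatter. Going by the values given here, compound 1 differs from compound 2 in two places at once, so no single step between measured compounds is available. Compound 3 `Cc1cc(O)cc(-c2nn(CC#N)cc2-c2ccnc(-c3ccc(N(C)C)cc3)c2)c1` differs from compound 2 only by hydrogen in place of methyl on an oxygen on an aromatic ring. With nothing to anchor that change, a step from compound 2 to compound 3 of about a 1.4-fold higher number from compound 2 to compound 3 (0.15 log units; within the scatter) is expected, with no firm direction. Compound 3 is therefore estimated at 450 nM, within 130 nM to 1500 nM.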

Compound 3, concentration for 50% growth inhibition: 2750 nM
Compound 3: middle estimate off by 6.1-fold (0.79 log units), on the low side; the measured number lies above the stated range.
By their numbers in this assay, from the lowest: compound 2; then compounds 1 and 3 (each within the scatter of the next).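

In this assay the change from methoxy to hydroxy on the 3-methoxy-5-methylphenyl group gives an 8.6-fold higher number from compound 2 to compound 3 (0.94 log units; beyond the scatter) and so gives this oxygen its first single-place reading, with the methyl on it tied to stronger growth inhibition. Dimethylamino in place of phenoxy on an aromatic carbon, with the hydroxy kept, gives a 1.2-fold higher number from compound 1 to compound 3 (0.08 log units; within the scatter) and does not separate these two compounds. Nothing shown here accounts for the effect of the methyl on this oxygen. On these data alone, it remains open whether an ethoxy group or a longer chain on that oxygen would keep the lower number, and whether an amine in place of the methoxy would do so. As far as these compounds go, it is also open whether methoxy would bring the same gain alongside phenoxy.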